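The source may report more compounds than this note shows. Statements on the series, on what has been measured and on what is new or still open speak of the compounds shown alone.

In a functional assay on the whole organism for inhibition, with Mus musculus as the target (on this read-out lower numbers stand for an effect already at smaller amounts and higher numbers for an effect only at larger amounts of compound), compound 1 (`Cc1ccc(C2CN(C)Cc3c(N)cccc32)cc1`) gives 1.6 mg/kg, compound 2 (`CCCCNC(=O)Nc1cccc2c1CN(C)CC2c1ccc(C)cc1`) gives 40 mg/kg and compound 3 (`CCNCC(=O)Nc1cccc2c1CN(C)CC2c1ccc(C)cc1`) gives about 45 mg/kg. Compound 3 thus stands level with compound 2, as a 1.1-fold higher number from compound 2 to compound 3 (0.05 log units; within the scatter) shows, and well away from compound 1. Compound 4 (`CCCCNCC(=O)Nc1cccc2c1CN(C)CC2c1ccc(C)cc1`) differs from compound 3 by ethyl in place of hydrogen on a saturated chain carbon, two bonds along the chain from an amine nitrogen: ethylamino becomes butylamino. The large steps, a 25-fold higher number from compound 1 to compound 2 (1.40 log units; beyond the scatter) and a 28-fold higher number from compound 1 to compound 3 (1.45 log units; beyond the scatter), both add a group on the nitrogen on the aromatic ring, which is not the place that changes here. The closer guide is a 1.1-fold higher number from compound 2 to compound 3 (0.05 log units; within the scatter), so no step beyond the scatter is expected in this assay. The estimate means a 1.1-fold lower number from compound 3 to compound 4 (0.05 log units; within the scatter). Compound 4 is expected at 40 mg/kg, with an estimated range of 16 mg/kg to 100 mg/kg.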

Compound 4, dose for half-maximal effect: 34 mg/kg
Beside the measured number, compound 4's estimate is 1.2-fold (0.07 log units) above it; low and high end bracket the measured number.
By their numbers in this assay, from the lowest: compound 1; then compounds 4, 2 and 3 (each within the scatter of the next).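

In this assay, ethyl in place of hydrogen on the saturated chain carbon, turning ethylamino into butylamino, leaves the reading unchanged within the scatter (a 1.3-fold lower number from compound 3 to compound 4 (0.12 log units; within the scatter)), so this position tolerates the longer chain. The same holds for (butylamino)methyl in place of butylamino on the carbonyl carbon (a 1.2-fold lower number from compound 2 to compound 4 (0.07 log units; within the scatter)), while the large gap to the free aromatic amine persists (a 21-fold higher number from compound 1 to compound 4 (1.33 log units; beyond the scatter)). No measurement here accounts for these readings. Still open, from the compounds shown here alone, is whether a carboxylic acid, a piperidine or a much longer chain in place of butylamino would keep this level.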